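The source may hold more compounds than are shown below. What is called first, only, known or untested is meant among the compounds shown, and "the series" means these compounds.

Measured compounds in an assay for inhibition of Nitric oxide synthase, inducible (Homo sapiens), read by scintillation counting, with a stated time of 30 min, tested at 1 mM; a higher number here means more inhibition at the concentration tested (going by the name of the read-out), a lower number less inhibition:

Compound 1, `CCCNC(=O)NCCC(O)c1ccccc1N`, gives 19%.
Compound 2, `Nc1ccccc1C(O)CCNC(=O)Nc1ccccc1`, gives 27.9%.
Compound 3, `CCCNC(=O)NCCC(O)c1cc(OC)ccc1N`, gives 14.7%.

Compound 4, `COc1ccc(N)c(C(O)CCNC(=O)Nc2ccccc2)c1`, has not yet been measured in this assay. It differs from compound 3 by phenyl in place of propyl on an amide-type nitrogen. The same change has already been made once among the measured compounds, from compound 1 to compound 2, where it reads (phenyl in place of propyl on an amide-type nitrogen); that step gave a number 8.9 percentage points higher from compound 1 to compound 2 (within the scatter). The two cores on which this change is made differ by methoxy in place of hydrogen on an aromatic carbon, and the step between those cores gave a number 4.3 percentage points lower from compound 1 to compound 3 (within the scatter). Compound 3 has the lowest of the three measured numbers, though its distance to compound 1 is within the scatter.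

Within the data shown here, since the change from compound 3 to compound 4 is the same as that from compound 1 to compound 2, and only one such step has been measured, the step from compound 3 to compound 4 is expected to be similar in size, about a number 8.9 percentage points higher from compound 3 to compound 4 (within the scatter), resting on the step of a number 8.9 percentage points higher from compound 1 to compound 2 (within the scatter). Compound 4 is therefore estimated at 23.6% in this assay, with a range from 10% to 37%.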

Compound 4, a percentage reported as inhibition, at one concentration (the size of the read-out at that concentration, not a potency): 12.3%
Beside the measured number, compound 4's estimate is 11.3 percentage points above it; measured number inside the range.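

In this assay, phenyl in place of propyl on the amide-type nitrogen of the core carrying the methoxy gave a number 2.4 percentage points lower from compound 3 to compound 4 (within the scatter), and this step does not differ from the earlier one by more than two such steps can: the same change on two cores in this assay, a number 8.9 percentage points higher (within the scatter) from compound 1 to compound 2 and a number 2.4 percentage points lower (within the scatter) from compound 3 to compound 4, 11.3 percentage points apart, within the scatter of two such steps. Methoxy in place of hydrogen on an aromatic carbon, read on the phenyl side, gave a number 15.6 percentage points lower from compound 2 to compound 4 (beyond the scatter), which lies beyond the scatter, yet it also stays within what can separate two such steps from the one on the propyl side: the same change on two cores in this assay, a number 4.3 percentage points lower (within the scatter) from compound 1 to compound 3 and a number 15.6 percentage points lower (beyond the scatter) from compound 2 to compound 4, 11.3 percentage points apart, within the scatter of two such steps. The result is thus compatible with the change carrying from one core to the other, but it does not establish this, since only two cores are shown and neither phenyl step lies beyond the scatter.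

The compounds shown leave open how a benzyl group or a longer chain on that nitrogen would read. They also leave open whether a chlorine or a hydroxyl group on the aromatic ring in place of methoxy would follow the same course.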